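Compound 4: A Ring Swap in a Series at Its Limit

A few compounds are considered here, and "the series" means these few. Any claim that something is new, unique, unknown or untested is made for them only; others in the source may bear on it.

In a functional assay on SMMC-7721 cells (Homo sapiens) for antiproliferative activity, read by MTT assay, with a stated time of 48 h (a higher number here means a weaker inhibitor, a lower number a stronger inhibitor), compound 3 `CN1CCN(CCCn2nc(C3=C(c4cn(C)c5ccccc45)C(=O)NC3=O)c3cccnc32)CC1` gives > 100000 nM, which is a limit and not a number. Compound 1 `Cn1cc(C2=C(c3nn(CCCn4cncn4)c4ncccc34)C(=O)NC2=O)c2ccccc21` also gives only a limit, > 100000 nM. Compound 2 `Cn1cc(C2=C(c3nn(CCCN4CCCCC4)c4ncccc34)C(=O)N(c3ccccn3)C2=O)c2ccccc21` likewise gives only a limit, > 100000 nM. The picture so far is therefore (the limit of > 100000 nM in this assay, at which 3 of the 3 values shown sit).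

Compound 4 `Cn1cc(C2=C(c3nn(CCCN4CCCCC4)c4ncccc34)C(=O)NC2=O)c2ccccc21` makes one change to compound 3: piperidin-1-yl in place of 4-methylpiperazin-1-yl on a saturated chain carbon, three bonds along the chain from an aromatic nitrogen. Piperidin-1-yl takes the place of 4-methylpiperazin-1-yl on a saturated chain carbon. Among the measured compounds shown here, the one measured step at this place is a step that the two limits leave unreadable from compound 1 to compound 3. With no readable size to build on, no change beyond the usual scatter is expected in this assay, in either direction. The expected step is a number no higher from compound 3 to compound 4 (the limit leaves the size open). Compound 4 is estimated at 100000 nM, within an expected range of 30000 nM to 200000 nM.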

Compound 4, half-maximal inhibitory concentration: 7670 nM
Compound 4: the middle estimate sits 13-fold (1.12 log units) above what was measured, and the stated range ends above it.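

In this assay, piperidin-1-yl in place of 4-methylpiperazin-1-yl gives an at least 13-fold lower number from compound 3 to compound 4 (1.11 log units; beyond the scatter), so the ring carried on this chain can decide whether a readable value appears. Piperidin-1-yl in place of 1H-1,2,4-triazol-1-yl gives an at least 13-fold lower number from compound 1 to compound 4 (1.11 log units; beyond the scatter), while hydrogen in place of pyridin-2-yl on the amide-type nitrogen gives an at least 13-fold lower number from compound 2 to compound 4 (1.11 log units; beyond the scatter), which makes that nitrogen a second sensitive place. Only compound 4 gives a number, and the other compounds rest on a limit: the limit of > 100000 nM in this assay, at which 3 of the 4 values shown sit.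

As far as these compounds go, the full size of each step stays open. So does whether morpholin-4-yl, a diethylamino group or a shorter chain would keep this activity.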